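The compounds below may be only part of what the source reports. "The series", "measured", "known", "first", "only" and "open" are said of these compounds alone.

For the measured compounds named here, compound 1, `COc1ccc(C(=O)Nc2c(F)cccc2Cl)cc1OC1CCCC1`, is the only compound in this set with a numeric result in an assay on isolated protein for inhibition of phosphodiesterase 4A (Sus scrofa) (a lower number here means a stronger inhibitor, a higher number a weaker inhibitor), where compound 1 gives 240 nM. The other measured compound, compound 2, `COc1ccc(C(=O)Nc2ccccc2Cl)cc1OC(=O)C1CCCC1`, returns only a limit in this assay, with compound 2 reported as > 1000000 nM, which marks the edge of the assay rather than a measured number. That limit is recorded as the limit of > 1000000 nM in this assay, at which 1 of the 2 values shown sits. Going by the values given here, no step between two measured compounds is available, so compound 1 stands alone as the reference point.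

Compound 3, `COc1ccc(C(=O)Nc2c(Br)cncc2Br)cc1OC1CCCC1`, differs from compound 1 in a single place: 3,5-dibromopyridin-4-yl in place of 2-chloro-6-fluorophenyl on an amide-type nitrogen. The amide, the methoxy group and the cyclopentyloxy group of the shared core are unchanged.

For compound 3 the expectation in this assay is a step toward stronger inhibition, beyond the usual scatter, estimated as a 12-fold lower number from compound 1 to compound 3 (1.08 log units; beyond the scatter). Compound 3 is accordingly expected to give about 20 nM in this assay, with the estimate ranging from 3 nM to 150 nM.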

Compound 3, half-maximal inhibitory concentration: 7 nM
Beside the measured number, compound 3's estimate is 2.9-fold (0.46 log units) above it; low and high end bracket the measured number.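

At the amide-type nitrogen of the shared core, the choice of ring makes a large difference in this assay: replacing 2-chloro-6-fluorophenyl with 3,5-dibromopyridin-4-yl gives a 34-fold lower number from compound 1 to compound 3 (1.54 log units; beyond the scatter). For the compounds shown here, until this pair, the set offered no step at all, so this is the first evidence that this position responds to a change while the amide, the methoxy group and the cyclopentyloxy group stay the same. The exchange keeps the count at 8 heavy atoms and a six-membered aromatic ring, while replacing a ring of carbon only with one holding a hetero atom and a hydrogen-bond acceptor, but nothing measured here explains the size of the step.

Going by these compounds alone, the single pair changes the ring nitrogen and both halogens together, so it remains open whether the nitrogen, the two bromine atoms or their combination accounts for the step. As far as these compounds go, how this position would respond to other groups, such as 3,5-dichloropyridin-4-yl or an unsubstituted pyridin-4-yl, and whether the gain would persist with a longer chain in place of cyclopentyloxy also remain open.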